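A Methyl Step Repeated on a Thiourea Analogue

A few compounds are considered here, and "the series" means these few. Any claim that something is new, unique, unknown or untested is made for them only; others in the source may bear on it.

Compound 1 `O=C(NCCNS(=O)(=O)c1sccc1-c1ccccc1Oc1ccc(O)c(O)c1)Nc1cc(Cl)cc(Cl)c1` and compound 2 `Cc1ccc(-c2ccsc2S(=O)(=O)NCCNC(=O)Nc2cc(Cl)cc(Cl)c2)c(Oc2ccc(O)c(O)c2)c1` differ in one place only: methyl in place of hydrogen on an aromatic carbon. In a functional assay on RS4-11 cells (Homo sapiens) for inhibition, read by CCK-8 assay, with a stated time of 48 h (a lower number here means a stronger inhibitor, a higher number a weaker inhibitor), compound 1 gives 6200 nM, and compound 2 gives 5100 nM. The step between them is a 1.2-fold lower number from compound 1 to compound 2 (0.08 log units; within the scatter), so the two numbers cannot be told apart.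

Compound 3 `O=S(=O)(NCCNC(=S)Nc1cc(C(F)(F)F)cc(C(F)(F)F)c1)c1sccc1-c1ccccc1Oc1ccc(O)c(O)c1` carries a different core; the difference between its core and that of compound 1 is not broken down here. In this assay compound 3 gives 4800 nM, a number that stays within the scatter of both compound 1 and compound 2.

Compound 4 `Cc1ccc(-c2ccsc2S(=O)(=O)NCCNC(=S)Nc2cc(C(F)(F)F)cc(C(F)(F)F)c2)c(Oc2ccc(O)c(O)c2)c1` has not yet been measured. It differs from compound 3 by methyl in place of hydrogen on an aromatic carbon, the same change that turns compound 1 into compound 2. For this assay the step is expected to be a 1.1-fold lower number from compound 3 to compound 4 (0.06 log units; within the scatter), set beside the earlier 1.2-fold lower number from compound 1 to compound 2 (0.08 log units; within the scatter); this expectation rests on the measured pair, because the pair showed a 1.2-fold lower number from compound 1 to compound 2 (0.08 log units; within the scatter) and nothing more. In this assay compound 4 is therefore estimated at 4200 nM, expected to fall between 2000 nM and 9000 nM.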

Compound 4, half-maximal inhibitory concentration: 4800 nM
Estimate against measurement, compound 4: 1.1-fold (0.06 log units) below; the range from low to high includes it.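

In this assay, methyl in place of hydrogen on the aromatic carbon gives no change at the digits printed from compound 3 to compound 4 (within the scatter), the same outcome in kind as on the core of compound 1. Set side by side, the two steps cannot be told apart: the same change on two cores in this assay, a 1.2-fold lower number (0.08 log units; within the scatter) from compound 1 to compound 2 and no change at the digits printed (within the scatter) from compound 3 to compound 4, 1.2-fold (0.08 log units) apart, within the scatter of two such steps. This shows that in these two pairs the change leaves the number within the scatter on both cores, but since neither step stands out from the scatter, no real effect of the methyl has been shown to carry from one core to the other, and two pairs say nothing about other cores or other assays.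

The compounds shown carry only hydrogen or methyl at this place, which leaves open whether a chlorine, a methoxy group or an amine there would give a step beyond the scatter. On these data alone, all four also keep the 3,4-dihydroxyphenoxy group, so what the methyl step does on a core with, for instance, a carboxylic acid in its stead remains open.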